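Adding a methyl to a saturated ring carbon of compound 1

This account rests on a few compounds, and the source may have more. Where it says the series, first, only, none or still open, it means among the compounds named here.

For the measured compounds named here, in a functional assay on MDA-MB-231 cells (Homo sapiens) for inhibition, read by sulforhodamine B assay, with a stated time of 74 h (on this read-out higher numbers stand for weaker inhibition and lower numbers for stronger inhibition), compound 1 (`Cc1ccc(S(=O)(=O)N2C(=O)COC23C=CC(=O)C=C3)cc1`) gives 70 nM, the only value that is a true number so far. Compound 2 (`CS(=O)(=O)N1C(=O)COC12C=CC(=O)C=C2`) reads > 10000 nM, which is a limit. Compound 3 (`O=C1C=CC2(C=C1)OCC(=O)N2S(=O)(=O)c1ccccc1`) reads > 10000 nM, which is also a limit.

Two measured steps leave compound 1, and both are large and beyond the scatter: an at least 140-fold higher number from compound 1 to compound 2 (2.15 log units; beyond the scatter) with methyl in place of 4-methylphenyl on a sulfonyl sulfur, and an at least 140-fold higher number from compound 1 to compound 3 (2.15 log units; beyond the scatter) with hydrogen in place of methyl on an aromatic carbon.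

Compound 4 (`Cc1ccc(S(=O)(=O)N2C(=O)C(C)OC23C=CC(=O)C=C3)cc1`) keeps the 4-methylphenyl group and differs elsewhere: methyl in place of hydrogen on a saturated ring carbon. This is methyl in place of hydrogen on a saturated ring carbon, next to the ring oxygen. Neither measured step touches that place, so neither sizes this change directly. Compound 4 keeps the aromatic methyl whose loss gave an at least 140-fold higher number from compound 1 to compound 3 (2.15 log units; beyond the scatter), so a step of that size is not the expectation in this assay, though the steepness of that step argues for a wide range on the upper side.

A modest move towards a higher number is expected, with the estimated step being a 2.3-fold higher number from compound 1 to compound 4 (0.36 log units; beyond the scatter). For compound 4 the estimated value is 160 nM, with an expected range of 40 nM to 1200 nM.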

Compound 4, half-maximal inhibitory concentration: 1100 nM
Compound 4: middle estimate off by 6.9-fold (0.84 log units), on the low side, and the stated range covers the measured number.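

In this assay, methyl in place of hydrogen on a saturated ring carbon, next to the ring oxygen, gives a 16-fold higher number from compound 1 to compound 4 (1.20 log units; beyond the scatter). The series therefore responds strongly at this position as well as on the sulfonyl side, and keeping the 4-methylphenyl group does not by itself preserve the number of compound 1. Compound 4 still gives a true number rather than a limit, which separates this change from the two changes to the group on the sulfonyl sulfur: the limit of > 10000 nM in this assay, at which 2 of the 4 values shown sit.

Still open, as far as these compounds go, is whether a different group on this saturated ring carbon, such as a hydroxyl, an amine or a longer chain like ethyl, would read closer to compound 1 or closer to compound 4, since a single methyl gives only one point at this position. From the compounds shown here alone, the step between compound 2 and compound 3 cannot be read, both values being limits, and it also remains open whether methoxy or chlorine in place of the aromatic methyl would hold the number of compound 1.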